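The source may report more compounds than this note shows. Statements on the series, on what has been measured and on what is new or still open speak of the compounds shown alone.

Of the compounds shown here, two sharing one core have been tested in a functional assay on MGC-803 cells (Homo sapiens) for inhibition, read by MTT assay, with a stated time of 48 h; a higher number here means a weaker inhibitor, a lower number a stronger inhibitor. Compound 1 `O=C(NC(=S)Nc1ccc(Cl)c(-c2nc3ccccc3[nH]2)c1)c1ccc(OCc2ccc(Cl)cc2Cl)cc1` gives 3030 nM. Compound 2 `Cc1ccc(NC(=O)NC(=O)c2ccc(OCc3ccc(C(F)(F)F)cc3)cc2)cc1-c1nc2ccccc2[nH]1` gives 14900 nM, the higher of the two numbers, and its gap from compound 1 lies beyond the usual scatter. Compound 3 `Cc1ccc(NC(=O)NC(=O)c2ccc(OCc3ccc(F)cc3)cc2)cc1-c1nc2ccccc2[nH]1` has not been measured; it differs from compound 2 in one place: fluoro in place of trifluoromethyl on an aromatic carbon. Among the measured compounds shown here, no measured pair shows this particular change, so its effect here is unknown. The step is expected to be a 1.0-fold higher number from compound 2 to compound 3 (0.00 log units; within the scatter), nothing beyond the scatter. Compound 3 is therefore estimated at 15000 nM, between 5000 nM and 45000 nM.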

Compound 3, half-maximal inhibitory concentration: 160 nM
Beside the measured number, compound 3's estimate is 94-fold (1.97 log units) above it, and the stated range ends above it.
By their numbers in this assay, from the lowest: compound 3; then compound 1; then compound 2.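

In this assay, fluoro in place of trifluoromethyl on an aromatic carbon para to a large group gives a 93-fold lower number from compound 2 to compound 3 (1.97 log units; beyond the scatter). Among the compounds shown here, compounds 1 and 2 differ in more than one place, so only this pair isolates the position and shows that one substituent there can change the number greatly. Nothing available explains the size of this step.

The compounds shown leave open how the number would respond to other groups at this position, such as methoxy, an amine or plain hydrogen. They also leave open whether the same change would have a similar effect in another compound.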